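The compounds below may be only part of what the source reports. "The series", "measured", "known", "first", "only" and "open" are said of these compounds alone.

Measured compounds:
compound 1 `Cc1ccccc1NC(=O)Nc1cc(C(C)(C)C)nn1-c1ccccc1`: 8.6 degrees C
compound 2 `CC(C)(C)c1cc(NC(=O)Nc2cc(C(F)(F)F)cc(C(F)(F)F)c2)n(-c2ccc(Br)cc2)n1`: -0.3 degrees C
compound 3 `CC(C)(C)c1cc(NC(=O)Nc2ccc(Cl)cc2)n(-c2ccc(C(F)(F)F)cc2)n1`: -0.6 degrees C

In an assay on isolated protein for inhibition of serine/threonine-protein kinase 10 (Homo sapiens), read by thermal shift assay, tested at 10 uM (on this read-out lower numbers stand for weaker stabilisation of the target and higher numbers for stronger stabilisation of the target against heat), compound 3 gives -0.6 degrees C, the lowest of the three numbers; compound 2 sits within the scatter of it, while compound 1 lies far beyond the scatter above it. Compound 4 `CC(C)(C)c1cc(NC(=O)Nc2ccc(Cl)cc2)n(-c2ccc(N)cc2)n1` differs from compound 3 in one place: amino in place of trifluoromethyl on an aromatic carbon. Among the measured compounds shown here, no step between measured compounds isolates this change, so its size is open. Compound 4 is expected to give 1.5 degrees C in this assay, within -1 degrees C to 5 degrees C; the step of a number 2.1 degrees C higher from compound 3 to compound 4 (beyond the scatter) is estimated to be small and upward, possibly not beyond the scatter, since compound 2 and compound 3 both sit near zero.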

Compound 4, shift of the target's melting temperature: 2 degrees C
Compound 4: middle estimate off by 0.50 degrees C, on the low side; the range from low to high includes it.
By their numbers in this assay, from the lowest: compounds 3 and 2 (each within the scatter of the next); then compound 4; then compound 1.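

In this assay, amino in place of trifluoromethyl on an aromatic carbon, para to a large group, gives a number 2.6 degrees C higher from compound 3 to compound 4 (beyond the scatter) in this series. Among the compounds shown here, this is the first change in one place that can be read here, and it shows that the group at this position can alter the stabilisation of the target.

On these data alone, whether the gain belongs to the amine itself or to the loss of trifluoromethyl stays open, as does how a hydroxyl, a methoxy group or a carboxylic acid would read at this place. What lies behind the step is open too, as nothing available bears on it.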